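The source may hold more compounds than are shown below. What is called first, only, known or untested is meant among the compounds shown, and "the series" means these compounds.

Measured compounds:
- compound 1, `NC(=O)[C@@H]1CCCN1Cc1cc(=O)oc2cc(OCc3ccccc3)ccc12`: 380 nM
- compound 2, `NC(=O)[C@@H]1CCCN1Cc1cc(=O)oc2cc(OCc3cccc(F)c3)ccc12`: 850 nM
- compound 3, `NC(=O)Cc1cc(=O)oc2cc(OCc3cccnc3)ccc12`: 1300 nM

In an assay for inhibition of Amine oxidase [flavin-containing] B (Rattus norvegicus) (a lower number here means a stronger inhibitor, a higher number a weaker inhibitor), compound 1 gives the lowest of the three numbers. Compound 2 sits nearest, with a 2.2-fold higher number from compound 1 to compound 2 (0.35 log units; beyond the scatter); compound 3 sits furthest, and its value 1300 nM beside that of compound 1 380 nM shows a larger gap, though the two structures differ in more than one place, so no single step can be read from them.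

The unmeasured compound 4, `CNCc1cc(=O)oc2cc(OCc3ccccc3)ccc12`, keeps the shared core of compound 1 and changes only the side group: methylamino in place of 2-carbamoylpyrrolidin-1-yl on a saturated chain carbon bound to an aromatic carbon. Within the data shown here, none of the measured steps touches this part of the molecule; the one step known, from compound 1 to compound 2, concerns a fluoro on an aromatic ring at the other end. There is therefore no measured guide for the size or direction of this change, and the expectation must stay wide. The estimate for compound 4 in this assay is 450 nM, with a range from 90 nM to 2300 nM, meaning an expected step of a 1.2-fold higher number from compound 1 to compound 4 (0.07 log units; within the scatter) that need not exceed the scatter.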

Compound 4, half-maximal inhibitory concentration: 28 nM
Compound 4: the middle estimate sits 16-fold (1.21 log units) above what was measured; the measured number lies below the stated range.
By their numbers in this assay, from the lowest: compound 4; then compound 1; then compounds 2 and 3 (each within the scatter of the next).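

In this assay, the side group on the saturated chain carbon bound to an aromatic carbon turns out to matter greatly: swapping 2-carbamoylpyrrolidin-1-yl for methylamino gives a 14-fold lower number from compound 1 to compound 4 (1.13 log units; beyond the scatter) and is the largest step seen so far. The entering group has 2 heavy atoms against 8 for the one that leaves, with no ring and no defined stereocentre, so neither the ring, the carbamoyl nor the stereocentre is needed for a low number on this core. No measurement shown here explains the size of this step.

Going by these compounds, this single swap changes all of these features at once, so their separate shares remain unknown. On these data alone, how pyrrolidin-1-yl without its carbamoyl, or a longer chain such as ethylamino, would compare with methylamino remains open, as does whether the fluoro step would repeat on compound 4.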